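Sulfonamide aryl exchange in the imidazolidinone series

A few compounds are considered here, and "the series" means these few. Any claim that something is new, unique, unknown or untested is made for them only; others in the source may bear on it.

Compound 2 `Cc1cc(C)cc(NS(=O)(=O)c2ccc(N3CCNC3=O)cc2)c1` holds the lowest of the two numbers in a functional assay on HT-29 cells (Homo sapiens) for antiproliferative activity, read by sulforhodamine B assay, with a stated time of 48 h (on this read-out lower numbers stand for stronger inhibition and higher numbers for weaker inhibition), where compound 2 gives 82 nM; compound 1 `O=C1NCCN1c1ccc(S(=O)(=O)Nc2ccc(I)cc2)cc1` gives 650 nM. Among the compounds with values here, the single measured step, a 7.9-fold lower number from compound 1 to compound 2 (0.90 log units; beyond the scatter), came from exchanging the aryl group on the same sulfonamide nitrogen, so that substituent clearly matters. Compound 3 `COc1ccccc1NS(=O)(=O)c1ccc(N2CCNC2=O)cc1` differs from compound 2 by 2-methoxyphenyl in place of 3,5-dimethylphenyl on a sulfonamide nitrogen. Because the earlier step at this place, a 7.9-fold lower number from compound 1 to compound 2 (0.90 log units; beyond the scatter), was beyond the scatter, a step of comparable size is expected here, and giving up the 3,5-dimethylphenyl is expected to raise the number: a 3.7-fold higher number from compound 2 to compound 3 (0.56 log units; beyond the scatter). Compound 3 is therefore estimated at 300 nM, with a range of 80 nM to 1500 nM.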

Compound 3, half-maximal inhibitory concentration: 550 nM
For compound 3 the middle estimate is 1.8-fold (0.26 log units) below the measured one, and the stated range covers the measured number.
By their numbers in this assay, from the lowest: compound 2; then compounds 3 and 1 (each within the scatter of the next).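

The change gives a 6.7-fold higher number from compound 2 to compound 3 (0.83 log units; beyond the scatter) in this assay and so shows that a second aryl group on the sulfonamide nitrogen also falls short of 3,5-dimethylphenyl. Set against 4-iodophenyl, 2-methoxyphenyl gives a 1.2-fold lower number from compound 1 to compound 3 (0.07 log units; within the scatter) and is not separated from it, which leaves compound 2 alone among the three. No measurement available here explains these differences. Still open, going by these compounds, is whether the 3,5-dimethylphenyl result depends on the two methyl groups, and whether 3,5-dimethoxyphenyl or 3,5-dichlorophenyl on the same nitrogen would give a number like that of compound 2.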